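The source may report more compounds than this note shows. Statements on the series, on what has been measured and on what is new or still open speak of the compounds shown alone.

Compound 1 `Cc1cccc(Nc2nc(C)c(C(=O)/C=C/c3ccc(Cl)cc3)s2)c1` gives in a functional assay on Bel-7402 cells (Homo sapiens) for cytotoxicity, read by MTT assay (on this read-out lower numbers stand for stronger inhibition and higher numbers for weaker inhibition), only a limit, > 25000 nM.
Compound 2 `COc1ccc(/C=C/C(=O)c2sc(Nc3ccc(Cl)c(Cl)c3)nc2C)cc1` gives in this assay only a limit, > 25000 nM.
Compound 3 `Cc1cccc(Nc2nc(C)c(C(=O)/C=C/c3ccccc3Cl)s2)c1` gives in this assay only a limit, > 25000 nM.

Compound 1 thus stands at a limit, not at a number, and so do the other two: the limit of > 25000 nM in this assay, at which 3 of the 3 values shown sit. Within the data shown here, the one measured step, a step that the two limits leave unreadable from compound 1 to compound 3, alters the group on the double-bonded chain carbon and is unreadable between two limits. Compound 4 `Cc1ccccc1Nc1nc(C)c(C(=O)/C=C/c2ccc(Cl)cc2)s1` is a rearrangement of compound 1: 2-methylphenyl in place of 3-methylphenyl on a nitrogen on an aromatic ring. Among the measured compounds shown here, no measured step touches the group on the nitrogen on the aromatic ring, so nothing argues for a change beyond the scatter. Compound 4 is expected at 30000 nM, from 10000 nM to 100000 nM, most likely again a limit. The expected step that the limit leaves unreadable from compound 1 to compound 4 is therefore none beyond the scatter.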

Compound 4, half-maximal inhibitory concentration: > 25000 nM
Compound 4 was reported as a limit; the forecaster's own chance of this, stated with the estimate: 80%; the middle value is on the limit's open side.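

No step can be read from compound 1 to compound 4, as both results are limits and not numbers: the limit of > 25000 nM in this assay, at which 4 of the 4 values shown sit.

The compounds shown leave open which change to the shared core, if any, would give a measurable number in this assay.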